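A few compounds are considered here, and "the series" means these few. Any claim that something is new, unique, unknown or untested is made for them only; others in the source may bear on it.

Compound 1, `COc1ccc(C(/C=C/c2ccc(F)cc2)=N/O)cc1`, was tested in a functional assay (Mus musculus, strain Balb/c) for inhibition, read by ELISA, with a stated time of 72 h (a lower number here means a stronger inhibitor, a higher number a weaker inhibitor), where compound 1 gives 11000 nM. Among the compounds with values here, its companion, compound 2, `COc1ccc(C(/C=C/c2ccccc2)=N/O)cc1`, gives 11800 nM in this assay; the single measured step, a 1.1-fold higher number from compound 1 to compound 2 (0.03 log units; within the scatter), is within the scatter, so the two compounds cannot be told apart, and compound 1 simply stands as the one whose number is nearest that of compound 2.

Compound 3, `Cc1ccc(C(/C=C/c2ccc(F)cc2)=N/O)cc1`, has not yet been measured. It differs from compound 1 in one place: methyl in place of methoxy on an aromatic carbon. Within the data shown here, the only measured step concerns the other ring, not the ring carrying this change, so no step here bears directly on it. Among the measured compounds shown here, with a small change and no guiding step, a step no larger than the scatter is expected in this assay, in no clear direction. Compound 3 is therefore expected to give about 12000 nM, between 5000 nM and 30000 nM, meaning an expected step of a 1.1-fold higher number from compound 1 to compound 3 (0.04 log units; within the scatter).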

Compound 3, half-maximal inhibitory concentration: 11300 nM
For compound 3 the middle estimate is 1.1-fold (0.03 log units) above the measured one; the range from low to high includes it.
By their numbers in this assay, from the lowest: compounds 1, 3 and 2 (each within the scatter of the next).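

In this assay, the step of a 1.0-fold higher number from compound 1 to compound 3 (0.01 log units; within the scatter) means that compound 1 and compound 3 cannot be told apart. Within the data shown here, this is the only measured change at this position, on an aromatic carbon para to a large group, and it shows that replacing methoxy with methyl, which removes the oxygen and the hydrogen-bond acceptor counted for methoxy, leaves the number within the scatter. No measured evidence is available to explain this result.

The compounds shown leave open whether a group of a different kind at this position, such as an amine or a carboxylic acid, or a longer chain such as butoxy, would move the number beyond the scatter. They also leave open what plain hydrogen at this position would give.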